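Oxygen-to-Sulfur Swap and Toxicity Toward Vero Cells

A few compounds are considered here, and "the series" means these few. Any claim that something is new, unique, unknown or untested is made for them only; others in the source may bear on it.

Four compounds are compared in an ADME assay on Vero cells (Chlorocebus sabaeus) for cytotoxicity, read by MTT assay, with a stated time of 96 h; on this read-out lower numbers stand for higher toxicity in this test and higher numbers for lower toxicity in this test. Compound 1 `C/C(=N\NC(N)=O)c1ccc2[nH]c(-c3ccc(C(F)(F)F)cc3)nc2c1` gives a value that is only a limit of the measurement, > 100000 nM. Compound 2 `C/C(=N\NC(N)=S)c1ccc2[nH]c(-c3ccc(C(F)(F)F)cc3)nc2c1` gives 22000 nM. Between the two lies a single change, (a group of 3 heavy atoms (1 carbon, 1 nitrogen, 1 sulfur; no ring) in place of a group of 3 heavy atoms (1 carbon, 1 nitrogen, 1 oxygen; no ring), on an amine nitrogen), and it produces an at least 4.5-fold lower number from compound 1 to compound 2 (0.65 log units; beyond the scatter); the size of this step is known only as a lower bound, because compound 1 sits at the limit of > 100000 nM in this assay, at which 2 of the 3 values shown sit.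

Compound 3 `C/C(=N\NC(N)=O)c1ccc2c(c1)nc(-c1ccccc1)n2C1CCCCC1` also gives only a limit, > 100000 nM. How its core differs from that of compound 1 is not broken down here. Compound 4 `C/C(=N\NC(N)=S)c1ccc2c(c1)nc(-c1ccccc1)n2C1CCCCC1` has not yet been measured; it differs from compound 3 by a group of 3 heavy atoms (1 carbon, 1 nitrogen, 1 sulfur; no ring) in place of a group of 3 heavy atoms (1 carbon, 1 nitrogen, 1 oxygen; no ring), on an amine nitrogen, the same change that separated compound 1 from compound 2.

A step of about the same direction and size is expected, an at least 4.0-fold lower number from compound 3 to compound 4 (0.60 log units; beyond the scatter). This expectation rests on compound 2, whose value 22000 nM followed the same change in an at least 4.5-fold lower number from compound 1 to compound 2 (0.65 log units; beyond the scatter). Compound 4 is therefore expected to give about 25000 nM, within a range from 8000 nM to 100000 nM.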

Compound 4, half-maximal cytotoxic concentration: 20000 nM
Beside the measured number, compound 4's estimate is 1.3-fold (0.10 log units) above it; the measured number falls inside the stated range.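

In this assay, putting the sulfur-bearing group in place of carbamoyl on the amine nitrogen again lowers the number, an at least 5.0-fold lower number from compound 3 to compound 4 (0.69 log units; beyond the scatter), which means higher toxicity in this test. Set beside the earlier step, the change points the same way on both cores, so in these two pairs the direction carries over from one core to the other: the same change on two cores in this assay, an at least 4.5-fold lower number (0.65 log units; beyond the scatter) from compound 1 to compound 2 and an at least 5.0-fold lower number (0.69 log units; beyond the scatter) from compound 3 to compound 4; the limit leaves it open whether they differ This does not show that the two steps are equal in size, nor how large either one truly is, because both oxygen-bearing compounds give only a limit: the limit of > 100000 nM in this assay, at which 2 of the 4 values shown sit.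

From the compounds shown here alone, two pairs also make no general rule for the series, so it remains open whether the same lower number would appear on a core carrying an amine, a carboxylic acid or a longer chain. Going by these compounds, it is equally open how the toxicity would respond if the terminal amine of the sulfur-bearing group carried a methyl group.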